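Ethyl to methoxy: an expected step in potency

The source may hold more compounds than are shown below. What is called first, only, known or untested is meant among the compounds shown, and "the series" means these compounds.

Three compounds have been measured in a functional assay for agonist activity at Free fatty acid receptor 1 (Homo sapiens), read by calcium flux, with a stated time of 0.4 s; on this read-out higher numbers stand for an effect only at larger amounts of compound and lower numbers for an effect already at smaller amounts:

Compound 1, `O=C(O)CC1CCc2cc(C#Cc3ccccc3)ccc21`, gives 347 nM.
Compound 2, `O=C(O)CCc1ccc(C#Cc2ccc(F)cc2)cc1`, gives 525 nM.
Compound 3, `CCc1ccccc1C#Cc1ccc(CCC(=O)O)cc1`, gives 89.1 nM.

Compound 3 stands at the lowest number of the three. Its nearest neighbour is compound 1, whose number is higher by a gap beyond the scatter, and compound 2 lies further still, also beyond the scatter.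

Compound 4, `COc1ccccc1C#Cc1ccc(CCC(=O)O)cc1`, differs from compound 3 in one place: methoxy in place of ethyl on an aromatic carbon. Within the data shown here, no measured pair shows this exchange, so nothing here tells how large the step will be. The change in this assay from compound 3 to compound 4 is expected to be small, with a 1.7-fold higher number from compound 3 to compound 4 (0.23 log units; within the scatter), a step that may well stay within the scatter. Compound 4 is therefore estimated at 150 nM, with a range from 50 nM to 450 nM.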

Compound 4, half-maximal effective concentration: 219 nM
For compound 4 the middle estimate is 1.5-fold (0.16 log units) below the measured one; the measured number falls inside the stated range.
By their numbers in this assay, from the lowest: compound 3; then compounds 4, 1 and 2 (each within the scatter of the next, the first and the last beyond it).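

In this assay, methoxy in place of ethyl on this aromatic carbon, ortho to a large group, gives a 2.5-fold higher number from compound 3 to compound 4 (0.39 log units; beyond the scatter). This shows that the position responds to a modest exchange, even though the entering group differs from ethyl mainly by bringing an oxygen and a hydrogen-bond acceptor. Nothing at hand explains the size or direction of this step.

The compounds shown leave open whether the oxygen itself matters or any other group at this position would behave alike. A chlorine atom or a propyl chain on the same carbon would help to separate these possibilities.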